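Changing the hydrazone aryl group on a triazine core

The source may report more compounds than this note shows. Statements on the series, on what has been measured and on what is new or still open speak of the compounds shown alone.

The series rests on a shared core carrying a sulfonamide-bearing aniline, a second aniline and a hydrazone arm. Compound 1, `NS(=O)(=O)c1ccc(Nc2nc(N/N=C/c3ccc(C(F)(F)F)cc3)nc(Nc3ccccc3)n2)cc1`, carries a 4-(trifluoromethyl)phenyl group on the hydrazone carbon; in a functional assay on HCC 2998 cells (Homo sapiens) for inhibition, read by sulforhodamine B assay, with a stated time of 48 h (a higher number here means a weaker inhibitor of growth, a lower number a stronger inhibitor of growth), compound 1 gives 2970 nM. Compound 2, `Cc1nn(-c2ccccc2)cc1/C=N/Nc1nc(Nc2ccccc2)nc(Nc2ccc(S(N)(=O)=O)cc2)n1`, gives 1880 nM, and the change a 1.6-fold lower number from compound 1 to compound 2 (0.20 log units; within the scatter) shows that swapping one aryl group for another at this position left the growth inhibition essentially unchanged. Among the measured compounds shown here, compound 2 therefore holds the lowest of the two numbers so far, but its step to compound 1 lies within the scatter, so no order between them can be claimed.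

Compound 3, `NS(=O)(=O)c1ccc(Nc2nc(N/N=C/c3ccccn3)nc(Nc3ccccc3)n2)cc1`, makes a further change at the same position: pyridin-2-yl in place of 3-methyl-1-phenyl-1H-pyrazol-4-yl on a carbon with a double bond to nitrogen. For the measured compounds named here, the only step that bears on this change, from compound 1 to compound 2, was within the scatter, so a similarly small step in this assay is expected, with no clear direction. The expected step is a 1.3-fold higher number from compound 2 to compound 3 (0.12 log units; within the scatter). Compound 3 is thus estimated at 2500 nM, within a range from 1000 nM to 6500 nM.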

Compound 3, concentration for 50% growth inhibition: 650 nM
Compound 3: the middle estimate sits 3.8-fold (0.59 log units) above what was measured; the whole stated range lies above it.
By their numbers in this assay, from the lowest: compound 3; then compounds 2 and 1 (each within the scatter of the next).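

Unlike the earlier swap at this position, the change to pyridin-2-yl on the carbon with a double bond to nitrogen moves the number in this assay beyond the scatter, with a 2.9-fold lower number from compound 2 to compound 3 (0.46 log units; beyond the scatter) and with a 4.6-fold lower number from compound 1 to compound 3 (0.66 log units; beyond the scatter) as the step from the 4-(trifluoromethyl)phenyl group. The position is therefore not indifferent to the group it carries, as the first pair alone might have suggested, although both steps are modest in size. Compound 3 is the strongest inhibitor of growth of the three, since its steps to the other two both lie beyond the scatter, while compounds 1 and 2 remain without an order between them. The data give no measured reason for this gain, so nothing can be said about why pyridin-2-yl stands apart.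

As far as these compounds go, it stays open whether the ring nitrogen of pyridin-2-yl matters in itself, a question that a plain phenyl group or pyridin-4-yl at this place would address. Also open, from the compounds shown here alone, is whether a shorter group, such as a methyl, or a ring bearing an amine or a carboxylic acid would carry the trend further.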